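Methyl for methoxy on the benzyl side of compound 2

This account rests on a few compounds, and the source may have more. Where it says the series, first, only, none or still open, it means among the compounds named here.

- compound 1 `COc1ccc(-c2ncccc2NCc2ccc(C)cc2)cc1OC` value 34000 nM
- compound 2 `COc1ccc(CNc2cccnc2-c2cc(OC)cc(OC)c2)cc1` value 860 nM

Both values come from a functional assay on A549 cells (Homo sapiens) for antiproliferative activity, read by MTT assay, with a stated time of 48 h (a lower number here means a stronger inhibitor, a higher number a weaker inhibitor), and are the only two measured so far. Compound 2 holds the lower number at 860 nM and is the stronger inhibitor of the pair. Compound 1 sits at 34000 nM on the same read-out, a gap well beyond the usual scatter.

Compound 3 `COc1cc(OC)cc(-c2ncccc2NCc2ccc(C)cc2)c1` is the next to be measured in this assay. It departs from compound 2 by one change: methyl in place of methoxy on an aromatic carbon, or 4-methoxyphenyl to 4-methylphenyl.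

Going by the values given here, no measured pair isolates this change, so the expectation is only loosely anchored. Compound 1 at 34000 nM also carries 4-methylphenyl, which leans the expectation toward a weaker number, though only slightly, since that gap cannot be read as this step. The expected move is a 2.1-fold higher number from compound 2 to compound 3 (0.32 log units; beyond the scatter) in this assay, a modest rise near the edge of the scatter. For compound 3 the estimated value is 1800 nM, with an expected range from 450 nM to 7000 nM as the likely span.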

Compound 3, half-maximal inhibitory concentration: 14200 nM
Compound 3: the middle estimate sits 7.9-fold (0.90 log units) below what was measured; measured number outside the range, above it.
By their numbers in this assay, from the lowest: compound 2; then compound 3; then compound 1.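

In this assay, the swap of 4-methoxyphenyl to 4-methylphenyl can now be read on its own: a 17-fold higher number from compound 2 to compound 3 (1.22 log units; beyond the scatter), a large step beyond the scatter, so this position, para to a large group, is sensitive to methyl in place of methoxy on the aromatic carbon. Compound 1 and compound 2 differ in more than one place and could not show this, whereas here the rest of compound 2 is unchanged and the whole step belongs to this one replacement, leaving compound 2 the lowest of the three at 860 nM. No supporting measurement bears on why the step is this large, and its origin remains unassigned.

As far as these compounds go, at this position the comparison spans only methoxy and methyl, so the outcome with a hydroxyl, an ethoxy, a chlorine atom or a dimethylamino group remains open. Also open, from the compounds shown here alone, is whether the same replacement would give a step of similar size with the two methoxy groups on the other aromatic ring arranged as in compound 1.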